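This account rests on a few compounds, and the source may have more. Where it says the series, first, only, none or still open, it means among the compounds named here.

Compound 1 `CCN1CCN(c2cccc3c2CN([C@H](CCCNCc2cccs2)c2ccc(OC)c(OC)c2)C3=O)CC1` shows the lowest number of the three measured in a functional assay on RMS13 cells for antagonist activity at Urotensin-2 receptor (Homo sapiens), read by FLIPR and calcium flux, with a stated time of 1 h; a higher number here means a weaker inhibitor, a lower number a stronger inhibitor; in that assay compound 1 gives 59 nM. Compound 2 `COc1ccc([C@@H](CCCN(C)S(=O)(=O)c2cccs2)N2Cc3c(cccc3N3CCN(C)CC3)C2=O)cc1OC` gives 340 nM in this assay, and compound 3 `COc1ccc([C@@H](CCCN(C)S(=O)(=O)c2cccs2)N2Cc3c(cccc3N3CCNCC3)C2=O)cc1OC` gives 410 nM. For the measured compounds named here, the only single-point step measured, a 1.2-fold higher number from compound 2 to compound 3 (0.08 log units; within the scatter), concerns the amine nitrogen in a ring of the shared core and says nothing about the chain substituent. Compound 4 `CCN1CCN(c2cccc3c2CN([C@H](CCCNC(=O)c2c(C)n[nH]c2C)c2ccc(OC)c(OC)c2)C3=O)CC1` differs from compound 1 by (3,5-dimethyl-1H-pyrazol-4-yl)carbonyl in place of (thiophen-2-yl)methyl on an amine nitrogen. Going by the values given here, no measured pair covers this kind of change, so the expectation rests on compound 1 alone and carries a wide range in both directions. Compound 4 is expected near 200 nM, between 40 nM and 1000 nM. The estimated step of a 3.4-fold higher number from compound 1 to compound 4 (0.53 log units; beyond the scatter) is thus tentative.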

Compound 4, half-maximal inhibitory concentration: 130 nM
Compound 4: the middle estimate sits 1.5-fold (0.19 log units) above what was measured; the measured number falls inside the stated range.
By their numbers in this assay, from the lowest: compound 1; then compound 4; then compounds 2 and 3 (each within the scatter of the next).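

In this assay, for the compounds shown here, the amine nitrogen on the chain, which no earlier step addressed, takes (3,5-dimethyl-1H-pyrazol-4-yl)carbonyl in place of (thiophen-2-yl)methyl at a modest cost (a 2.2-fold higher number from compound 1 to compound 4 (0.34 log units; beyond the scatter)). This position therefore keeps measurable activity when the secondary amine becomes an amide carrying a different five-membered aromatic ring. No available evidence accounts for the size of this step.

The change alters the linking unit and the ring together, so their separate contributions stay unresolved. A (thiophen-2-yl)carbonyl or (3,5-dimethyl-1H-pyrazol-4-yl)methyl group on the same nitrogen would separate them.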